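Methoxy Gives Way to Ethyl on the Shared Core

This account rests on a few compounds, and the source may have more. Where it says the series, first, only, none or still open, it means among the compounds named here.

Three compounds share a core carrying a 2,4-dichlorophenyl group, and all were tested in an assay on IMR-32 cells for displacement of a labelled ligand from corticotropin-releasing factor receptor 1 (Homo sapiens), read by scintillation counting, with a stated time of 2 h; on this read-out lower numbers stand for stronger inhibition and higher numbers for weaker inhibition. Compound 1 `CCc1nc(NC(CC)CC)c(OC)nc1-c1ccc(Cl)cc1Cl` gives 5.9 nM. Compound 3 `CCc1nc(-c2ccc(Cl)cc2Cl)c(OC)nc1NC(CC)CC` gives 8 nM, a number that sits within the scatter of compound 1 and so cannot be ranked against it. Compound 2 `CCc1nc(-c2ccc(Cl)cc2Cl)c(CC)nc1NC(C)CN(C)C` differs from compound 3 in two places at once; compound 2 gives 489 nM, a number far beyond the scatter of compound 3. Among the three, compound 3 therefore stands close to compound 1 and far from compound 2.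

Compound 4 `CCc1nc(-c2ccc(Cl)cc2Cl)c(CC)nc1NC(CC)CC` is not yet measured. Going by the values given here, its single difference from compound 3 is ethyl in place of methoxy on an aromatic carbon. Among the compounds with values here, no pair of measured compounds differs only in this way, so no measured step shows what it does; compound 2 carries the ethyl but also a different amine, which blurs the reading. The expected step in this assay from compound 3 to compound 4 is a modest rise, a 2.5-fold higher number from compound 3 to compound 4 (0.40 log units; beyond the scatter), and the estimated value for compound 4 is 20 nM, within a range from 5 nM to 80 nM.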

Compound 4, inhibition constant: 4.1 nM
For compound 4 the middle estimate is 4.9-fold (0.69 log units) above the measured one; the whole stated range lies above it.
By their numbers in this assay, from the lowest: compounds 4, 1 and 3 (each within the scatter of the next); then compound 2.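

In this assay, ethyl can take the place of methoxy on this aromatic carbon, ortho to a 2,4-dichlorophenyl group, with no loss that can be read: the step is a 2.0-fold lower number from compound 3 to compound 4 (0.29 log units; within the scatter). The same swap at the methoxy of compound 1, which sits elsewhere on the shared core, gives a 1.4-fold lower number from compound 1 to compound 4 (0.16 log units; within the scatter), so neither methoxy oxygen is needed for binding at this level, and with ethyl present in both compounds, a 120-fold lower number from compound 2 to compound 4 (2.08 log units; beyond the scatter) ties the large gap to the group on the nitrogen alone. Nothing here measures why these groups behave this way.

Going by these compounds, whether a longer chain such as propyl, or a small group such as chlorine, would be accepted on this carbon remains open. So does whether a cyclic group such as cyclopentyl on the nitrogen would hold up as well as pentan-3-yl.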